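Methoxy added to the amide-bearing ring of compound 1

A few compounds are considered here, and "the series" means these few. Any claim that something is new, unique, unknown or untested is made for them only; others in the source may bear on it.

Measured so far:
compound 1, `CC(C)(CNC(=O)c1ccc2ccccc2c1)CC1=C(O)C(=O)c2ccccc2C1=O`, 28200 nM
compound 2, `COC1=C(CC(C)(C)CNC(=O)c2ccc3ccccc3c2)C(=O)c2ccccc2C1=O`, 52500 nM
compound 3, `COc1ccccc1C(=O)NCC(C)(C)CC1=C(O)C(=O)c2ccccc2C1=O`, 111000 nM

All numbers come from a functional assay on MCF7 cells (Homo sapiens) for cytotoxicity, read by resazurin assay, with a stated time of 3 days; on this read-out higher numbers stand for weaker inhibition and lower numbers for stronger inhibition. Compound 1 stands lowest of the three; compound 2 is nearest, within the scatter, and compound 3 furthest, beyond it. Compound 4, `COc1c(C(=O)NCC(C)(C)CC2=C(O)C(=O)c3ccccc3C2=O)ccc2ccccc12`, differs from compound 1 by methoxy in place of hydrogen on an aromatic carbon. For the measured compounds named here, no measured step places a methoxy on this ring alone. The step of a 1.9-fold higher number from compound 1 to compound 2 (0.27 log units; within the scatter) adds a methyl on an oxygen elsewhere and stays within the scatter. The step of a 3.9-fold higher number from compound 1 to compound 3 (0.60 log units; beyond the scatter) brings in a methoxy on the amide-bearing ring but also replaces that ring, and is modest. For compound 4 a small rise in the number is therefore expected, a 1.5-fold higher number from compound 1 to compound 4 (0.17 log units; within the scatter). The estimate for compound 4 is 42000 nM, with a range from 15000 nM to 120000 nM.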

Compound 4, half-maximal inhibitory concentration: 39800 nM
For compound 4 the middle estimate is 1.1-fold (0.02 log units) above the measured one; measured number inside the range.
By their numbers in this assay, from the lowest: compounds 1, 4 and 2 (each within the scatter of the next); then compound 3.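

Methoxy in place of hydrogen on this aromatic carbon, ortho to a large group, gives a 1.4-fold higher number from compound 1 to compound 4 (0.15 log units; within the scatter), so this position accepts the group with no step beyond the scatter. Methoxy alone on this ring therefore does not reproduce the larger step seen with compound 3, where the ring itself is replaced. Nothing at hand bears on the reason for this result.

From the compounds shown here alone, whether an amine, a carboxylic acid or a longer alkoxy chain on this carbon would fare the same remains open. So does the outcome of methoxy on the other aromatic carbons of this ring.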